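Chain length at the amide of a dioxolane cytosine series

This account rests on a few compounds, and the source may have more. Where it says the series, first, only, none or still open, it means among the compounds named here.

Measured compounds:
compound 1, `CCCCC(=O)Nc1ccn([C@@H]2CO[C@H](CO)O2)c(=O)n1`: 9130 nM
compound 2, `CCCCCCCCCC(=O)Nc1ccn([C@@H]2CO[C@H](CO)O2)c(=O)n1`: 40 nM
compound 3, `CCCCCCCCCCCC(=O)Nc1ccn([C@@H]2CO[C@H](CO)O2)c(=O)n1`: 30 nM

In a functional assay on SW1573 cells (Homo sapiens) for cytotoxicity, read by sulforhodamine B assay, with a stated time of 72 h (on this read-out higher numbers stand for weaker inhibition and lower numbers for stronger inhibition), compound 1 gives the highest number of the three measured compounds. The steps of a 230-fold lower number from compound 1 to compound 2 (2.36 log units; beyond the scatter) and a 300-fold lower number from compound 1 to compound 3 (2.48 log units; beyond the scatter) both describe a longer chain on the amide carbonyl and both are large; between the two longer chains the step of a 1.3-fold lower number from compound 2 to compound 3 (0.12 log units; within the scatter) is within the scatter.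

Compound 4, `O=C(Nc1ccn([C@@H]2CO[C@H](CO)O2)c(=O)n1)C1CC1`, differs from compound 1 by cyclopropyl in place of butyl on a carbonyl carbon. The change goes the other way from the measured steps: the group on the carbonyl carbon becomes smaller rather than longer. Among the measured compounds shown here, no measured pair covers a shortening or a ring at this position, so the direction of the expected step rests only on the two large steps from compound 1 toward longer chains. On that basis no lowering of the number is expected for compound 4; a number within the scatter of compound 1, or somewhat higher, is the expectation, with the step estimated as a 1.6-fold higher number from compound 1 to compound 4 (0.22 log units; within the scatter). Compound 4 is estimated at 15000 nM in this assay, within a range of 5000 nM to 50000 nM.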

Compound 4, half-maximal inhibitory concentration: 22000 nM
For compound 4 the middle estimate is 1.5-fold (0.17 log units) below the measured one, within the range that was stated.
By their numbers in this assay, from the lowest: compounds 3 and 2 (each within the scatter of the next); then compound 1; then compound 4.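

In this assay, among the compounds shown here, the step of a 2.4-fold higher number from compound 1 to compound 4 (0.38 log units; beyond the scatter) is the first change at this position that raises the number, and it is modest beside the large falls a 230-fold lower number from compound 1 to compound 2 (2.36 log units; beyond the scatter) and a 300-fold lower number from compound 1 to compound 3 (2.48 log units; beyond the scatter). The position therefore responds in both directions from compound 1, and the order now has compound 4 at the high end and compounds 2 and 3 at the low end, but this single pair changes the butyl for the cyclopropyl and so alters both the group's size and the presence of a ring at once. Nothing available here explains the rise, and no measurement separates the contribution of the ring from that of the smaller group.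

A propyl on the same carbonyl carbon would separate the ring from the chain length, while a hexyl chain would help show where, from butyl toward the longer chains, the numbers begin to fall. Also open, on these data alone, are whether a larger ring such as cyclohexyl follows cyclopropyl or the chains, and whether an amine or carboxylic acid at the end of a longer chain retains the low numbers of compounds 2 and 3.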